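This account rests on a few compounds, and the source may have more. Where it says the series, first, only, none or still open, it means among the compounds named here.

Compound 3 `Cn1ccc2cc(Nc3ncc4cc(S(=O)(=O)c5ccc(F)cc5F)c(=O)n(C)c4n3)ccc21` carries the lowest number of the three compounds measured in a functional assay on K562 cells (Homo sapiens) for inhibition, read by trypan blue exclusion, with a stated time of 72 h; on this read-out higher numbers stand for weaker inhibition and lower numbers for stronger inhibition: compound 3 gives 750 nM. Compound 1 `Cn1c(=O)c(S(=O)(=O)c2ccc(F)cc2F)cc2cnc(Nc3cccc4[nH]ccc34)nc21` gives 1500 nM, and since the step of a 2.0-fold lower number from compound 1 to compound 3 (0.30 log units; within the scatter) lies within the scatter the two cannot be ordered. Compound 2 `Cn1c(=O)c(S(=O)(=O)c2ccc(F)cc2F)cc2cnc(Nc3ccc4occc4c3)nc21` gives 15000 nM; the step of a 20-fold lower number from compound 2 to compound 3 (1.30 log units; beyond the scatter) and the step of a 10-fold higher number from compound 1 to compound 2 (1.00 log units; beyond the scatter) both lie beyond the scatter. Compound 4 `Cn1c(=O)c(S(=O)(=O)c2ccc(F)cc2F)cc2cnc(Nc3ccc4cccc(O)c4n3)nc21` differs from compound 3 in one place: 8-hydroxyquinolin-2-yl in place of 1-methyl-1H-indol-5-yl on a nitrogen on an aromatic ring. Among the measured compounds shown here, none of the measured steps involves 8-hydroxyquinolin-2-yl, so no direct guide exists. The two steps beyond the scatter do show that exchanging the group on this nitrogen can move this assay by a large amount, and the exchange a 10-fold higher number from compound 1 to compound 2 (1.00 log units; beyond the scatter), which put 1-benzofuran-5-yl in place of 1H-indol-4-yl, raised the number. Compound 4 is therefore expected to show a higher number, a 4.0-fold higher number from compound 3 to compound 4 (0.60 log units; beyond the scatter), with wide uncertainty. For compound 4 the estimate is 3000 nM, within a range from 500 nM to 20000 nM.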

Compound 4, half-maximal inhibitory concentration: 5000 nM
Estimate against measurement, compound 4: 1.7-fold (0.22 log units) below; low and high end bracket the measured number.
By their numbers in this assay, from the lowest: compounds 3 and 1 (each within the scatter of the next); then compound 4; then compound 2.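

In this assay, among the compounds shown here, 8-hydroxyquinolin-2-yl is the first group on this nitrogen to have no five-membered aromatic ring, and the exchange costs some inhibition but does not remove it: a 6.7-fold higher number from compound 3 to compound 4 (0.82 log units; beyond the scatter) and a 3.3-fold higher number from compound 1 to compound 4 (0.52 log units; beyond the scatter) both raise the number, while a 3.0-fold lower number from compound 2 to compound 4 (0.48 log units; beyond the scatter) lowers it. All three steps lie beyond the scatter, so the new group falls inside the range already set by the earlier groups rather than outside it, with compound 4 between compound 2 and the pair of compound 1 and compound 3. Nothing given here accounts for where compound 4 falls.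

The hydroxy group cannot be separated from the quinoline that carries it, as the only quinolin-2-yl shown bears that group. On these data alone, whether a methoxy group or an amine on that ring would move the number remains open.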